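Shifting the hydroxyl on two outer rings

A few compounds are considered here, and "the series" means these few. Any claim that something is new, unique, unknown or untested is made for them only; others in the source may bear on it.

Measured compounds:
compound 1 `Oc1ccccc1-c1cc(-c2ccc(OC(F)(F)F)cc2)cc(-c2ccccc2O)n1` — > 50000 nM
compound 2 `Oc1cccc(-c2cc(-c3cccc(OC(F)(F)F)c3)cc(-c3ccccc3O)n2)c1` — 2740 nM
compound 3 `Oc1cccc(-c2cc(-c3ccc(OC(F)(F)F)cc3)cc(-c3ccccc3O)n2)c1` — 9410 nM

All three were tested in a functional assay on HCT-15 cells (Homo sapiens) for inhibition; a lower number here means a stronger inhibitor, a higher number a weaker inhibitor. Compound 1 reaches only a limit of that assay, > 50000 nM, and no number is known for it. Compound 3 gives 9410 nM in this assay. Compound 2 gives 2740 nM, the lowest of the two numbers.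

Compound 1 and compound 3 differ in one place: 3-hydroxyphenyl in place of 2-hydroxyphenyl on an aromatic carbon. This change made an at least 5.3-fold lower number from compound 1 to compound 3 (0.72 log units; beyond the scatter); the step can only be given as a lower bound because of the limit of > 50000 nM in this assay, at which 1 of the 3 values shown sits. How the core of compound 1 differs from the core of compound 2 is not broken down here.

Compound 4 `Oc1cccc(-c2cc(-c3cccc(OC(F)(F)F)c3)cc(-c3cccc(O)c3)n2)c1` is not yet measured. It stands to compound 2 as compound 3 stands to compound 1: 3-hydroxyphenyl in place of 2-hydroxyphenyl on an aromatic carbon. The surroundings are not identical: in compound 1 the changed group is meta to a 2-hydroxyphenyl group, in compound 2 it is meta to a 3-hydroxyphenyl group, so this is the same kind of change rather than the same change. From the compounds shown here alone, a step in the same direction as the earlier one is expected, though its true size is unknown since compound 1 gave only a limit; the expected step is a 2.7-fold lower number from compound 2 to compound 4 (0.44 log units; beyond the scatter). Compound 4 is therefore estimated at 1000 nM in this assay, with a likely range from 300 nM to 4000 nM.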

Compound 4, half-maximal inhibitory concentration: > 50000 nM
Compound 4: no number, only a limit; the forecaster's own chance of this, stated with the estimate: 5%; middle value at least 50-fold (1.69 log units) away from the limit.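

In this assay compound 4 gives > 50000 nM, which is a limit of the assay and not a number. Putting 3-hydroxyphenyl in place of 2-hydroxyphenyl gives an at least 18-fold higher number from compound 2 to compound 4 (1.26 log units; beyond the scatter), the opposite direction to the earlier step, so in this series the change did not carry over from one core to the other, and its effect on one core did not predict its effect on the other: the same change on two cores in this assay, an at least 5.3-fold lower number (0.72 log units; beyond the scatter) from compound 1 to compound 3 and an at least 18-fold higher number (1.26 log units; beyond the scatter) from compound 2 to compound 4, at least 96-fold (1.98 log units) apart, beyond the scatter of two such steps These two pairs show that the direction of the step depends on the surrounding structure, but they do not explain why it reverses, and they give neither step an exact size, as each of the two steps rests on a value that is only a limit: the limit of > 50000 nM in this assay, at which 2 of the 4 values shown sit.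

The compounds shown leave open how the same change would behave on further cores, as two pairs are too few to give a rule for when the step goes up and when it goes down. They also leave open whether the hydroxyl itself is needed on these outer rings, or whether an amine or a carboxylic acid in its place would give a measurable number in this assay.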